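The source may hold more compounds than are shown below. What is called first, only, known or untested is meant among the compounds shown, and "the series" means these compounds.

Compound 1, `CCCn1c(=O)[nH]c2nc(-c3ccc(S(=O)(=O)N4CCN(c5ccc(Cl)cc5F)CC4)cc3)[nH]c2c1=O`, gives > 1000 nM in an assay on CHO cells for displacement of a labelled ligand from adenosine receptor A1 (Homo sapiens), read by scintillation counting, with a stated time of 90 min, in the presence of a further agent that is not named here (on this read-out higher numbers stand for weaker inhibition and lower numbers for stronger inhibition), a limit of the assay.
Compound 2, `CCCn1c(=O)[nH]c2nc(-c3ccc(S(=O)(=O)N4CCN(c5cccc(Cl)c5)CC4)cc3)[nH]c2c1=O`, gives > 1000 nM in this assay, also a limit.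
Compound 3, `CCCn1c(=O)[nH]c2nc(-c3ccc(S(=O)(=O)N4CCN(c5ccccc5)CC4)cc3)[nH]c2c1=O`, gives 364 nM in this assay.

Compound 2 therefore stands at the limit, the same one compound 1 reaches (the limit of > 1000 nM in this assay, at which 2 of the 3 values shown sit), while compound 3 alone yields a number. The step to compound 4, `CCCn1c(=O)[nH]c2nc(-c3ccc(S(=O)(=O)N4CCN(c5ccc(I)cc5)CC4)cc3)[nH]c2c1=O`, is 4-iodophenyl in place of 3-chlorophenyl on an amine nitrogen in a ring. Going by the values given here, no measured step exchanges one halogen for another: the nearest evidence is an at least 2.7-fold lower number from compound 2 to compound 3 (0.43 log units; beyond the scatter), which shows the chloro-free ring binding more strongly, and a step that the two limits leave unreadable from compound 1 to compound 2, which stays unreadable. With compound 1 and compound 2 both at the limit, compound 4 is expected to remain weak, and a step that the limit leaves unreadable from compound 2 to compound 4 is estimated. Compound 4 is thus expected to give roughly 2000 nM, somewhere between 600 nM and 8000 nM.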

Compound 4, inhibition constant: > 1000 nM
Compound 4: a limit, no number; the forecaster's own chance of this, stated with the estimate: 70%; the middle value is on the limit's open side.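

In this assay, iodo in place of hydrogen on the aromatic carbon gives an at least 2.7-fold higher number from compound 3 to compound 4 (0.43 log units; beyond the scatter), so the unsubstituted phenyl now stands apart from 4-iodophenyl as well as from 3-chlorophenyl. Compound 4 gives only a limit of the assay, like the two other halogen-bearing compounds: the limit of > 1000 nM in this assay, at which 3 of the 4 values shown sit. The steps among these three compounds cannot be read, so 4-iodophenyl, 3-chlorophenyl and 4-chloro-2-fluorophenyl remain unordered.

From the compounds shown here alone, how far past the limit these three compounds lie stays open. So does whether a methyl or methoxy group on this ring would behave like the halogens or like hydrogen.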